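Chloro to methoxy on a chalcone-like pair of benzazole ketones

The source may hold more compounds than are shown below. What is called first, only, known or untested is meant among the compounds shown, and "the series" means these compounds.

Compound 1 `O=C(/C=C/c1cccc(Cl)c1)c1nc2ccccc2s1` was tested in a functional assay on HCT-116 cells (Homo sapiens) for antiproliferative activity, read by MTT assay, with a stated time of 48 h; on this read-out lower numbers stand for stronger inhibition and higher numbers for weaker inhibition. In this assay compound 1 gives only a limit, > 100000 nM, and no number. Compound 2 `O=C(/C=C/c1cccc(Cl)c1)c1nc2ccccc2o1` likewise gives only a limit in this assay, > 100000 nM. Among the compounds with values here, compound 1 therefore stands at the edge of what this assay resolves, since the limit of > 100000 nM in this assay, at which 2 of the 2 values shown sit, describes both recorded values, and no step between measured compounds is available.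

Compound 3 `COc1cccc(/C=C/C(=O)c2nc3ccccc3s2)c1` is made from compound 1 by a single exchange, (methoxy in place of chloro on an aromatic carbon); in words, methoxy in place of chloro on an aromatic carbon. Within the data shown here, no measured step offers a guide for this exchange. With compound 1 resting at the limit, the step from compound 1 to compound 3 is expected to be a number no higher from compound 1 to compound 3 (the limit leaves the size open), most probably none beyond the scatter. Compound 3 is accordingly estimated at 100000 nM in this assay, within a range of 20000 nM to 300000 nM, and it is expected that the assay may again report only a limit.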

Compound 3, half-maximal inhibitory concentration: > 100000 nM
Compound 3: a limit, no number (the forecaster's own chance of this, stated with the estimate: 70%); the middle value sits exactly at the limit.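

Compound 3, like compound 1, gives only a limit in this assay, so no step can be read between these two compounds: the limit of > 100000 nM in this assay, at which 3 of the 3 values shown sit. The compounds shown leave open how strongly any of them inhibits and whether methoxy in place of chloro alters this.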